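Working notes: from compound 3 to compound 4

The compounds below may be only part of what the source reports. "The series", "measured", "known", "first", "only" and "open" are said of these compounds alone.

In a functional assay on MDA-MB-231 cells (Homo sapiens) for inhibition, read by MTT assay, with a stated time of 5 days (on this read-out higher numbers stand for weaker inhibition and lower numbers for stronger inhibition), compound 3 `Cc1cc(Nc2nc(NCc3ccccc3Br)nc3[nH]ncc23)n[nH]1` gives 3990 nM, level with compound 2 `Cc1cc(Nc2nc(NCc3ccccc3Cl)nc3[nH]ncc23)n[nH]1` at 4210 nM, and both stand clear of compound 1 `Cc1cc(Nc2nc(NCc3ccccc3F)nc3[nH]ncc23)n[nH]1` at 9850 nM. Compound 4 `Cc1cc(Nc2nc(NCc3cccc(Cl)c3)nc3[nH]ncc23)n[nH]1` carries 3-chlorophenyl in place of 2-bromophenyl on a saturated chain carbon bound to a nitrogen on an aromatic ring. The halogen steps bear on this only in part: a 2.3-fold lower number from compound 1 to compound 2 (0.37 log units; beyond the scatter) and a 2.5-fold lower number from compound 1 to compound 3 (0.39 log units; beyond the scatter) are modest, while a 1.1-fold lower number from compound 2 to compound 3 (0.02 log units; within the scatter) stays within the scatter. For the measured compounds named here, no measured compound carries 3-chlorophenyl, so that part of the change has no measured step. A small step towards a higher number in this assay is expected, a 1.3-fold higher number from compound 3 to compound 4 (0.10 log units; within the scatter). Compound 4 is estimated at 5000 nM, with a range of 2000 nM to 12000 nM.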

Compound 4, half-maximal inhibitory concentration: 6860 nM
The estimate for compound 4 lay 1.4-fold (0.14 log units) below the measured number; low and high end bracket the measured number.
By their numbers in this assay, from the lowest: compounds 3, 2, 4 and 1 (each within the scatter of the next, the first and the last beyond it).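

3-chlorophenyl in place of 2-chlorophenyl gives a 1.6-fold higher number from compound 2 to compound 4 (0.21 log units; within the scatter) in this assay, so on this position the two chlorophenyl groups cannot be told apart. The other two steps, a 1.7-fold higher number from compound 3 to compound 4 (0.24 log units; within the scatter) and a 1.4-fold lower number from compound 1 to compound 4 (0.16 log units; within the scatter), also stay within the scatter, so compound 4 does not separate from compound 1 or compound 3, although those two stand apart from each other. Nothing available explains these results. Still open, going by these compounds, is how a methoxy or nitrile on the phenyl ring, or a longer chain in place of the benzyl group, would read here.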